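A few compounds are considered here, and "the series" means these few. Any claim that something is new, unique, unknown or untested is made for them only; others in the source may bear on it.

Measured in an ADME assay on MT4 cells (Homo sapiens) for cytotoxicity, read by MTT assay, with a stated time of 4 days; a lower number here means that less compound is tolerated, a higher number that more compound is tolerated:
compound 1, `Cc1ccc(/C=N/NC(=O)COc2cccc3ccccc23)cc1`: 83.9 ug/mL
compound 2, `O=C(COc1cccc2ccccc12)N/N=C/c1ccccc1O`: 5.19 ug/mL
compound 3, `O=C(COc1cccc2ccccc12)N/N=C/c1ccc(F)cc1`: 65.1 ug/mL

Compound 3 stands second highest of the three numbers; its nearest neighbour is compound 1, the gap being within the scatter, while compound 2 lies far below it (a 13-fold higher number from compound 2 to compound 3 (1.10 log units; beyond the scatter)). The step to compound 4 `O=C(COc1cccc2ccccc12)N/N=C/c1cccc(Cl)c1` is 3-chlorophenyl in place of 4-fluorophenyl on a carbon with a double bond to nitrogen. Going by the values given here, no measured step bears directly on this change. Among the compounds with values here, the only comparison between two substituted phenyls without the hydroxyl is a 1.3-fold lower number from compound 1 to compound 3 (0.11 log units; within the scatter), within the scatter, whereas the large steps of a 16-fold lower number from compound 1 to compound 2 (1.21 log units; beyond the scatter) and a 13-fold higher number from compound 2 to compound 3 (1.10 log units; beyond the scatter) both involve the 2-hydroxyphenyl, which compound 4 does not carry. Within the data shown here, a halogen exchange together with a move of the substituent to the 3-position has no precedent in these three compounds, so the expectation rests on the small size of the methyl-to-fluoro step alone. Relative to compound 3, compound 4 is therefore expected to show a 1.1-fold lower number from compound 3 to compound 4 (0.04 log units; within the scatter), no step beyond the scatter. The estimate for compound 4 in this assay is 60 ug/mL, ranging from 25 ug/mL to 130 ug/mL.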

Compound 4, half-maximal cytotoxic concentration: 89.9 ug/mL
Compound 4: the middle estimate sits 1.5-fold (0.18 log units) below what was measured, and the stated range covers the measured number.
By their numbers in this assay, from the lowest: compound 2; then compounds 3, 1 and 4 (each within the scatter of the next).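

In this assay, exchanging the halogen and moving it on the ring together does not separate the two compounds (a 1.4-fold higher number from compound 3 to compound 4 (0.14 log units; within the scatter)), so this position accepts that double change without a step beyond the scatter. The same holds against the 4-methylphenyl (a 1.1-fold higher number from compound 1 to compound 4 (0.03 log units; within the scatter)), which leaves 4-methylphenyl, 4-fluorophenyl and 3-chlorophenyl inseparable, while 2-hydroxyphenyl stands clearly apart from the new compound too (a 17-fold higher number from compound 2 to compound 4 (1.24 log units; beyond the scatter)). Nothing measured here accounts for the gap between compound 2 and the other three compounds.

As far as these compounds go, whether the low number of compound 2 belongs to the hydroxyl itself stays open; a phenyl carrying a methoxy group or an amine would test this. Also open, from the compounds shown here alone, is what a carboxylic acid on the phenyl, or a saturated alkyl chain in its place, would give on this carbon.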